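Methyl on the benzoyl ring across two hydrazone cores

A few compounds are considered here, and "the series" means these few. Any claim that something is new, unique, unknown or untested is made for them only; others in the source may bear on it.

Measured so far:
compound 1 `O=C(N/N=C/C1=C(Cl)c2ccccc2CCC1)c1ccccc1`: > 100000 nM
compound 2 `Cc1ccc(C(=O)N/N=C/C2=C(Cl)c3ccccc3CCC2)cc1`: 300 nM
compound 3 `Cc1cc2c(cc1C)C(Cl)=C(/C=N/NC(=O)c1ccccc1)CCC2`: > 100000 nM

In a functional assay on HeLa cells (Homo sapiens) for inhibition, read by sulforhodamine B assay, with a stated time of 48 h (on this read-out higher numbers stand for weaker inhibition of growth and lower numbers for stronger inhibition of growth), compound 1 reports only a limit, > 100000 nM. Compound 2 gives 300 nM in this assay. Going by the values given here, the one change between them is methyl in place of hydrogen on an aromatic carbon, and it brings an at least 330-fold lower number from compound 1 to compound 2 (2.52 log units; beyond the scatter). Since compound 1 sits at the limit of > 100000 nM in this assay, at which 2 of the 3 values shown sit, that step is known only as a floor.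

Compound 3 carries a different core; the difference between the cores of compound 1 and compound 3 is not broken down here. In this assay compound 3 also reports only a limit, > 100000 nM.

Compound 4 `Cc1ccc(C(=O)N/N=C/C2=C(Cl)c3cc(C)c(C)cc3CCC2)cc1` has not yet been measured. It differs from compound 3 by methyl in place of hydrogen on an aromatic carbon, the same change as that from compound 1 to compound 2. For compound 4 the expected step is an at least 50-fold lower number from compound 3 to compound 4 (1.69 log units; beyond the scatter), resting on an at least 330-fold lower number from compound 1 to compound 2 (2.52 log units; beyond the scatter). Compound 4 is expected near 2000 nM, between 200 nM and 50000 nM.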

Compound 4, concentration for 50% growth inhibition: > 100000 nM
Compound 4 gave a limit, no number; the forecaster's own chance of this, stated with the estimate: 30%; at least 50-fold (1.69 log units) between middle value and limit.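

No step can be read from compound 3 to compound 4 in this assay, since each reports only a limit: the limit of > 100000 nM in this assay, at which 3 of the 4 values shown sit.

The compounds shown leave open whether the change from phenyl to 4-methylphenyl lowers the number at all on the core of compound 3.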